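This account rests on a few compounds, and the source may have more. Where it says the series, first, only, none or still open, it means among the compounds named here.

Working notes on the series.

Three compounds sharing one core have been run through an ADME assay on cells (Homo sapiens) for cytotoxicity, read by polymerase chain reaction, with a stated time of 3 days; on this read-out higher numbers stand for lower toxicity in this test and lower numbers for higher toxicity in this test. Compound 1 `Cc1nc(NC(C)(C)C)nc(N[C@@H]2C[C@H](CO)[C@@H](O)[C@H]2O)c1-c1nc2ccccc2s1` gives 12000 nM. Compound 2 `Cc1nc(NCC2CC2)nc(N[C@@H]2C[C@H](CO)[C@@H](O)[C@H]2O)c1-c1nc2ccccc2s1` gives 8000 nM. Compound 3 `Cc1nc(Nc2ccccc2)nc(N[C@@H]2C[C@H](CO)[C@@H](O)[C@H]2O)c1-c1nc2ccccc2s1` returns only a limit of the assay, > 25000 nM, so its position is known as a bound and not as a number; it sits at the limit of > 25000 nM in this assay, at which 1 of the 3 values shown sits. The steps among the measured compounds: a 1.5-fold lower number from compound 1 to compound 2 (0.18 log units; within the scatter); an at least 2.0-fold higher number from compound 1 to compound 3 (0.31 log units; beyond the scatter); an at least 3.1-fold higher number from compound 2 to compound 3 (0.49 log units; beyond the scatter).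

The next compound, compound 4 `Cc1nc(NCc2ccccc2)nc(N[C@@H]2C[C@H](CO)[C@@H](O)[C@H]2O)c1-c1nc2ccccc2s1`, differs from compound 3 in one place: benzyl in place of phenyl on a nitrogen on an aromatic ring. Going by the values given here, no measured step covers this particular exchange. Among the compounds with values here, the steps that bear on it are those where a group on that nitrogen was traded for a different one: both changes away from an alkyl group toward phenyl moved the number up to the limit, while the trade between the two alkyl groups stayed within the scatter. Benzyl carries the same aromatic ring as phenyl but attached through an added carbon, so the expectation in this assay is a step from compound 3 to compound 4 that is either none beyond the scatter or a modest move downward, an at least 1.6-fold lower number from compound 3 to compound 4 (0.22 log units; that floor lies within the scatter), with a fair chance that compound 4 again reads only a limit. Compound 4 is therefore estimated at 15000 nM, within a range of 6000 nM to 40000 nM.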

Compound 4, half-maximal cytotoxic concentration: 9000 nM
Beside the measured number, compound 4's estimate is 1.7-fold (0.22 log units) above it, within the range that was stated.
By their numbers in this assay, from the lowest: compounds 2, 4 and 1 (each within the scatter of the next). At a limit, above all of these: compound 3.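

In this assay, the change from anilino to benzylamino gives an at least 2.7-fold lower number from compound 3 to compound 4 (0.44 log units; beyond the scatter), so at this nitrogen the presence of the aromatic ring does not by itself go with the reading of compound 3; the added carbon that separates the ring from the nitrogen counts in this test. Compound 3 reads only a limit of the assay, so this step is a floor and its full size stays unknown: the limit of > 25000 nM in this assay, at which 1 of the 4 values shown sits. Compared with the two alkyl compounds, benzyl gives a 1.1-fold higher number from compound 2 to compound 4 (0.05 log units; within the scatter) and a 1.3-fold lower number from compound 1 to compound 4 (0.12 log units; within the scatter), which places compound 4 with them and leaves phenyl, set directly on the nitrogen in compound 3, as the only group shown that stands apart.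

The compounds shown leave open whether the reading of compound 3 is particular to phenyl or also holds for another aromatic group on that nitrogen, such as pyridyl. They also leave open whether a longer chain ending in the same ring, such as phenethyl, stays with compound 4, and whether a hydroxyl or an amine on the phenyl of compound 3 keeps the reading at the limit.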